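Replacing methoxy with chloro on an aromatic ring

This account rests on a few compounds, and the source may have more. Where it says the series, first, only, none or still open, it means among the compounds named here.

Of the compounds shown here, three sharing one core have been measured in a physicochemical assay for lipophilicity, at pH 7.4; a higher number here means a more lipophilic compound, a lower number a more polar compound. Compound 3 (`COc1ccccc1C1Cc2nccn2C1`) gives 1.9, and compound 1 (`Fc1ccccc1C1Cc2nccn2C1`), which lies within the scatter of it, gives 2. Compound 2 (`c1ccc(C2Cc3nccn3C2)cc1`) gives 1.9; 2.2 (2 entries), which shows how far separate entries for a single compound can lie apart.

The next compound to be measured is compound 4 (`Clc1ccccc1C1Cc2nccn2C1`), which carries chloro in place of methoxy on an aromatic carbon. Going by the values given here, only one measured step bears on this change, methoxy in place of fluoro: a number 0.10 log units lower from compound 1 to compound 3 (within the scatter). Among the compounds with values here, that step is small and offers only a rough guide, and no measured compound yet carries chloro. A modest rise in this assay is nevertheless expected, and the estimated step is a number 0.50 log units higher from compound 3 to compound 4 (beyond the scatter). For compound 4 the estimated value is 2.4, with an expected range from 2 to 2.8.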

Compound 4, distribution coefficient: 2.6
Estimate against measurement, compound 4: 0.20 log units below; low and high end bracket the measured number.
By their numbers in this assay, from the lowest: compounds 3 and 1 (each within the scatter of the next); then compound 4.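

At this aromatic carbon, ortho to a group of 8 heavy atoms, the choice of group can now be seen to matter in this assay: fluoro and methoxy lie within the scatter of each other, but chloro stands apart, with a number 0.70 log units higher from compound 3 to compound 4 (beyond the scatter) and with a number 0.60 log units higher from compound 1 to compound 4 (beyond the scatter). So the first clear separation at this place comes with chloro, although it rests on compound 4 alone. Both steps are modest but lie beyond the scatter, and separate entries for a single compound can differ noticeably: the several entries of compound 2 in this assay, 1.9; 2.2 (2 entries).

From the compounds shown here alone, how an amine or a carboxylic acid at this same place would read in this assay stays open. Also open, going by these compounds, is whether the step to chloro would hold on a different core.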